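This account rests on a few compounds, and the source may have more. Where it says the series, first, only, none or still open, it means among the compounds named here.

Working notes on the series. Compound 1 `COc1cc2c(=O)c(C(=O)c3ccc(C)cc3)cn(CCCc3ccccc3)c2cc1OC`, compound 2 `COc1cc2c(=O)c(C(=O)c3ccc(C)cc3)cn(Cc3ccc(Cl)c(Cl)c3)c2cc1OC` and compound 3 `COc1cc2c(=O)c(C(=O)c3ccc(C)cc3)cn(Cc3ccc(S(C)(=O)=O)cc3)c2cc1OC` share one core and differ only in the group on the aromatic nitrogen. In an ADME assay on Huh-7 cells (Homo sapiens) for cytotoxicity (on this read-out lower numbers stand for stronger inhibition of growth and higher numbers for weaker inhibition of growth), compound 1 gives "not active" (no number reported). In this assay compound 2 likewise gives "not active" (no number reported). Compound 3 is reported in this assay only as a limit of the assay, > 50000 nM, not as a number. No pair of these compounds is connected by a step with a number, so no size of a step can be read; what is seen is that none of the three shows an inhibition of growth that yields a single value. Where compound 3 stands is therefore told by the limit of > 50000 nM in this assay, at which 1 of the 3 values shown sits, with the other two entries giving no number at all.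

Compound 4 `COc1cc2c(=O)c(C(=O)c3ccc(C)cc3)cn(CC3CC3)c2cc1OC` is not yet measured in this assay. It differs from compound 3 in one place: cyclopropyl in place of 4-(methylsulfonyl)phenyl on a saturated chain carbon bound to an aromatic nitrogen.

Given that compound 3 sits at > 50000 nM and compounds 1 and 2 give no number, the expectation for compound 4 is no step beyond the scatter, and most likely again a limit, so a step that the limit leaves unreadable from compound 3 to compound 4 is estimated as essentially flat. Compound 4 is expected to give about 70000 nM in this assay, with a range from 20000 nM to 250000 nM.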

Compound 4, concentration for 50% growth inhibition: "not active" (no number reported)
Nothing numeric was reported for compound 4, and the estimate cannot be compared.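

Among the compounds shown here, no step from compound 3 to compound 4 can be read in this assay: compound 4 gives "not active" (no number reported). Compound 3 stands only as a limit of the assay, > 50000 nM. The compounds shown leave open whether any group on the aromatic nitrogen of the shared core gives a single value for inhibition of growth in this assay.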